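The source may report more compounds than this note shows. Statements on the series, on what has been measured and on what is new or still open speak of the compounds shown alone.

Two compounds share one core and differ only in the group carried on an amide-type nitrogen in a ring. Compound 1 `CC(C)[C@@H]1CC[C@@H](C)C[C@@]12N(C)C(=O)[C@@H]1[C@H]3C(=O)N(C)C(=O)[C@H]3ON12` carries a methyl there, and in a functional assay, read by spectrophotometry, with a stated time of 2 h, tested at 1 mg/mL (a higher number here means a stronger effect of the compound at the concentration tested, a lower number a weaker effect), compound 1 gives 41.5%. Compound 2 `CC(C)[C@@H]1CC[C@@H](C)C[C@@]12N(C)C(=O)[C@@H]1[C@H]3C(=O)N(c4ccccc4)C(=O)[C@H]3ON12` carries a phenyl instead, and in this assay compound 2 gives 29.7%, the lower of the two numbers, the change being a number 11.8 percentage points lower from compound 1 to compound 2 (beyond the scatter), a modest drop that lies beyond the scatter. Compound 3 `Cc1cccc(N2C(=O)[C@H]3[C@H](ON4[C@@H]3C(=O)N(C)[C@@]43C[C@H](C)CC[C@H]3C(C)C)C2=O)c1` takes one further step from compound 2: methyl in place of hydrogen on an aromatic carbon. Among the compounds with values here, no measured pair shows what a methyl added to that phenyl does. Within the data shown here, the one step seen, methyl to phenyl on the nitrogen, concerns a different place and a far larger change, so it offers little guidance here. With nothing pointing in either direction, a shift no larger than the scatter is expected, and the estimated step is a number 1.7 percentage points lower from compound 2 to compound 3 (within the scatter). Compound 3 is therefore expected to give 28% in this assay, with a range from 14% to 42%.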

Compound 3, a percentage reported as activity, at one concentration (the size of the read-out at that concentration, not a potency): 25.8%
Estimate against measurement, compound 3: 2.2 percentage points above; low and high end bracket the measured number.
By their numbers in this assay, from the lowest: compounds 3 and 2 (each within the scatter of the next); then compound 1.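

In this assay, adding a methyl to the phenyl, on an aromatic carbon meta to a large group, gives a small step (a number 3.9 percentage points lower from compound 2 to compound 3 (within the scatter)), so this one extra carbon leaves the read-out of compound 3 not distinguishable from that of compound 2. Placing 3-methylphenyl instead of methyl on the amide-type nitrogen gives a second step (a number 15.7 percentage points lower from compound 1 to compound 3 (beyond the scatter)), so the lower number seen with phenyl in place of that methyl is also seen when the aromatic ring bears this added methyl. Nothing available explains either step, and the numbers stand as observations only.

Still open, on these data alone, is whether a different group at this same place on the aromatic ring, such as a methoxy, a chlorine, an amine or a carboxylic acid, would give a step beyond the scatter. Also open, as far as these compounds go, is what a non-aromatic group on the amide-type nitrogen, such as an ethyl or a longer chain, would do to the read-out, and whether the number seen with methyl there can be exceeded.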